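Branching the alkyl chain on the core: butyl to isobutyl

A few compounds are considered here, and "the series" means these few. Any claim that something is new, unique, unknown or untested is made for them only; others in the source may bear on it.

Measured compounds:
compound 1 `Cc1cc(C(=O)O)nn1Cc1cc(Cl)cc2cc(C3CCCC3)nn12` 410 nM
compound 2 `CCCCc1cc2cc(Cl)cc(Cn3nc(C(=O)O)cc3C)n2n1` 1900 nM

In a functional assay on cells for antagonist activity at prostaglandin E2 receptor EP1 subtype (Rattus norvegicus), read by fluorescence and calcium flux, with stated times of 90 min and 60 s (a lower number here means a stronger inhibitor, a higher number a weaker inhibitor), compound 2 gives the higher of the two numbers, with compound 1 the nearer and only comparator at 410 nM. Compound 3 `Cc1cc(C(=O)O)nn1Cc1cc(Cl)cc2cc(CC(C)C)nn12` differs from compound 2 by isopropyl in place of propyl on a saturated chain carbon bound to an aromatic carbon. Going by the values given here, the one step that bears on this is a 4.6-fold higher number from compound 1 to compound 2 (0.67 log units; beyond the scatter), where the compact cyclopentyl ring gave the lower number and the open butyl chain the higher. A branched isobutyl sits between these two shapes, so a modest move back toward the number of compound 1 is expected, though a single step is a thin basis. Compound 3 is estimated at 1000 nM (400 nM to 2500 nM), an expected 1.9-fold lower number from compound 2 to compound 3 (0.28 log units; within the scatter).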

Compound 3, half-maximal inhibitory concentration: 1400 nM
Estimate against measurement, compound 3: 1.4-fold (0.15 log units) below, and the stated range covers the measured number.
By their numbers in this assay, from the lowest: compound 1; then compounds 3 and 2 (each within the scatter of the next).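

In this assay branching the butyl chain to isobutyl leaves the number within the scatter (a 1.4-fold lower number from compound 2 to compound 3 (0.13 log units; within the scatter)). The gap to the cyclopentyl compound remains beyond the scatter for the branched chain too (a 3.4-fold higher number from compound 1 to compound 3 (0.53 log units; beyond the scatter)), so at this position it is not confined to the straight butyl chain. No measurement available here accounts for that gap.

Still open, as far as these compounds go, is how a smaller ring such as cyclopropyl or a larger one such as cyclohexyl would read at this position. From the compounds shown here alone, a shorter chain such as ethyl is equally open.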